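This account rests on a few compounds, and the source may have more. Where it says the series, first, only, none or still open, it means among the compounds named here.

Working notes on the series. In an ADME assay on HEK-293T cells (Homo sapiens) for cytotoxicity, read by CCK-8 assay, with a stated time of 48 h (on this read-out lower numbers stand for stronger inhibition and higher numbers for weaker inhibition), compound 1 (`O=S(=O)(NCCNC(=S)Nc1cccc(Cl)c1)c1ccc(-c2ccccc2OCc2cccc(O)c2)s1`) gives 17400 nM, compound 2 (`O=[N+]([O-])c1ccc(NC(=S)NCCNS(=O)(=O)c2ccc(-c3ccccc3O[C@H]3CC[C@@H](O)CC3)s2)cc1`) gives 20000 nM and compound 3 (`O=S(=O)(NCCNC(=S)Nc1cccc(Cl)c1)c1ccc(-c2ccccc2OCc2ccccc2)s1`) gives 10200 nM. All three values lie within the scatter of one another, so on these numbers compound 3 is not separated from the other two.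

Compound 4 (`Cc1cc(C)cc(NC(=O)NCCNS(=O)(=O)c2ccc(-c3ccccc3OCc3ccccc3)s2)c1`) differs from compound 3 in one place: a group of 11 heavy atoms (9 carbon, 1 nitrogen, 1 oxygen; one six-membered aromatic ring of carbon only) in place of a group of 10 heavy atoms (7 carbon, 1 nitrogen, 1 sulfur, 1 chlorine; one six-membered aromatic ring of carbon only), on an amine nitrogen. The entering group is (3,5-dimethylphenyl)carbamoyl.

For the measured compounds named here, the only measured single-place step, a 1.7-fold lower number from compound 1 to compound 3 (0.23 log units; within the scatter), is hydrogen in place of hydroxy on an aromatic carbon. That is a different change, and the step stays within the scatter. Going by the values given here, no measured step replaces the group on the amine nitrogen alone. Compound 2, at 20000 nM, carries another group there but also differs from compound 3 in a second place, and its value is within the scatter of compound 3. The measured compounds thus give no sign of a move in either direction in this assay, although the evidence is thin.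

The expected change is a 1.2-fold higher number from compound 3 to compound 4 (0.07 log units; within the scatter), which means no step beyond the scatter. For compound 4 the estimate is 12000 nM, with an expected range of 5000 nM to 30000 nM.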

Compound 4, half-maximal inhibitory concentration: > 20000 nM
Compound 4 gave a limit, no number; the forecaster's own chance of this, stated with the estimate: 10%; middle value at least 1.6-fold (0.22 log units) from the limit.
By their numbers in this assay, from the lowest: compounds 3, 1 and 2 (each within the scatter of the next).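

On the amine nitrogen, this assay now has its first step that changes this position alone: (3,5-dimethylphenyl)carbamoyl enters in place of the group in compound 3, giving an at least 1.9-fold higher number from compound 3 to compound 4 (0.29 log units; that floor lies within the scatter). The floor of this step does not establish a move at this position, but the step is open upward, so a real change of unknown size is not excluded. Compound 4 is the only one of the compounds shown to be reported as a limit and not a number: the limit of > 20000 nM in this assay, at which 1 of the 4 values shown sits.

The entering group differs from the one it replaces in two ways at once, with oxygen in place of sulfur and a different set of atoms on the aromatic ring, and the compounds shown do not separate these two changes. Also open, on these data alone, is how this assay responds on this amine nitrogen to a group with no aromatic ring, or to an aromatic group carrying an amine or a carboxylic acid, and whether either would give a number rather than a limit.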